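Shortening a bromoalkyl chain on a brominated diaryl ether

This account rests on a few compounds, and the source may have more. Where it says the series, first, only, none or still open, it means among the compounds named here.

Of the compounds shown here, three built on a shared core have been tested in a functional assay on U-937 cells (Homo sapiens) for cytotoxicity, read by MTT assay, with a stated time of 24 h; a higher number here means a weaker inhibitor, a lower number a stronger inhibitor. Compound 1 `Brc1ccc(Oc2cc(Br)cc(Br)c2OCCCCCN2CCN(C/C=C/c3ccccc3)CC2)c(Br)c1` gives 32.7 ug/mL. Compound 2 `Brc1ccc(Oc2cc(Br)cc(Br)c2OCc2ccccc2)c(Br)c1` gives 29 ug/mL. Compound 3 `BrCCCCCCOc1c(Br)cc(Br)cc1Oc1ccc(Br)cc1Br` gives 33.8 ug/mL. Compound 3 thus sits among the three numbers with gaps to compound 1 and compound 2 that are both within the usual scatter, so no real difference between them can be claimed.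

Compound 4 `BrCCCCOc1c(Br)cc(Br)cc1Oc1ccc(Br)cc1Br` is compound 3 with one change: bromo in place of 2-bromoethyl on a saturated chain carbon, four bonds along the chain from an oxygen on an aromatic ring.

Within the data shown here, only one measured step touches this part of the molecule. Going a 1.2-fold higher number from compound 2 to compound 3 (0.07 log units; within the scatter) swapped the group attached to the chain carbon on the aromatic oxygen and left the readout essentially unchanged. That step is not the same change as the one here, but it is the nearest guide, and it suggests the chain on this oxygen has little influence on cytotoxicity within the scatter of this assay.

For compound 4 in this assay, the step of a 1.0-fold lower number from compound 3 to compound 4 (0.01 log units; within the scatter) is therefore expected to stay within the scatter. The estimate for compound 4 is 33 ug/mL, with a likely range from 20 ug/mL to 55 ug/mL.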

Compound 4, half-maximal inhibitory concentration: 29 ug/mL
Compound 4: the middle estimate sits 1.1-fold (0.06 log units) above what was measured; the range from low to high includes it.
By their numbers in this assay, from the lowest: compounds 2, 4, 1 and 3 (each within the scatter of the next).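

In this assay, removing the 2-bromoethyl end and leaving bromo in its place shortens the bromoalkyl chain while keeping a bromine at its end, and this gives a 1.2-fold lower number from compound 3 to compound 4 (0.07 log units; within the scatter). The leaving piece has 3 heavy atoms and the entering one has 1, so within these two compounds, this difference in chain length cannot be told apart from the scatter of repeated measurements. The comparison with the aromatic group gives no change at the digits printed from compound 2 to compound 4 (within the scatter), showing that 3-bromopropyl in place of phenyl also leaves no difference that can be claimed, and nothing available explains why these changes leave the number where it is.

Still open, on these data alone, is whether a group of a different kind at the end of the chain, such as a carboxylic acid or a hydroxyl in place of the terminal bromine, or a much longer chain, would produce a step beyond the scatter. The compounds shown also keep the bromines on the shared core throughout, so the effect of replacing one of them with chloro or hydrogen remains unknown.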